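The source may hold more compounds than are shown below. What is called first, only, known or untested is meant among the compounds shown, and "the series" means these compounds.

Compound 1, with the structure `O=c1[nH]cc(S(=O)(=O)Nc2ccccc2-c2cn(-c3cccc(F)c3)nn2)c(=O)[nH]1`, opens the set. In a functional assay on HepG2 cells (Homo sapiens) for antiproliferative activity, read by MTT assay, with a stated time of 24 h (on this read-out lower numbers stand for stronger inhibition and higher numbers for weaker inhibition), compound 1 gives > 20000 nM, which is a limit of the assay and not a number. Compound 2, with the structure `O=c1[nH]cc(S(=O)(=O)Nc2ccccc2-c2cn(-c3ccc(F)cc3)nn2)c(=O)[nH]1`, differs from it only in that (4-fluorophenyl in place of 3-fluorophenyl on an aromatic nitrogen). In this assay compound 2 gives > 20000 nM, again a limit. Between them lies a step that the two limits leave unreadable from compound 1 to compound 2. Compound 3, with the structure `O=c1[nH]cc(S(=O)(=O)Nc2cccc(-c3cn(-c4cccc(F)c4)nn3)c2)c(=O)[nH]1`, carries a different core; how the two cores differ is not broken down here. In this assay compound 3 gives > 20000 nM, once more a limit. Notably, the limit of > 20000 nM in this assay, at which 3 of the 3 values shown sit, holds for every value so far.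

Compound 4, with the structure `O=c1[nH]cc(S(=O)(=O)Nc2cccc(-c3cn(-c4ccc(F)cc4)nn3)c2)c(=O)[nH]1`, is the one not yet measured; relative to compound 3, (4-fluorophenyl in place of 3-fluorophenyl on an aromatic nitrogen). The surroundings of the change are the same in both pairs, so this is the same change already seen in the first pair. The expected step is a step that the limit leaves unreadable from compound 3 to compound 4, which rests on the earlier pair, where the change gave a step that the two limits leave unreadable from compound 1 to compound 2 and left no readable movement. Compound 4 is therefore expected to come out near 25000 nM, estimated between 10000 nM and 60000 nM, most likely as another limit.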

Compound 4, half-maximal inhibitory concentration: > 20000 nM
Compound 4 gave a limit, no number; the forecaster's own chance of this, stated with the estimate: 85%; the middle value does not contradict the limit.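

Going by these compounds alone, compound 3 and compound 4 both sit at a limit of the assay and not at a number, so the step between them cannot be read and this result yields no new step. The compounds shown leave open whether 3-fluorophenyl and 4-fluorophenyl, or the two cores, differ at all in this assay, because every result rests on one shared limit: the limit of > 20000 nM in this assay, at which 4 of the 4 values shown sit.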